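The source may report more compounds than this note shows. Statements on the series, on what has been measured and on what is new or still open speak of the compounds shown alone.

For the measured compounds named here, compound 1 `COc1ccc(-c2cc(/C=C/C(=O)c3ccc(N)cc3)[nH]n2)cc1` is the only member of the series with a number in a functional assay on SF-295 cells (Homo sapiens) for inhibition, read by sulforhodamine B assay, with a stated time of 48 h; on this read-out lower numbers stand for stronger inhibition of growth and higher numbers for weaker inhibition of growth; in this assay compound 1 gives 3090 nM. Compound 2 `COc1ccc(C(=O)/C=C/c2cc(-c3cc(OC)c(OC)c(OC)c3)n[nH]2)cc1OC` and compound 3 `COc1ccc(C(=O)/C=C/c2cc(-c3cc(OC)c(OC)c(OC)c3)n[nH]2)cc1` carry no result: in this assay compound 2 gives "not determined" (no result reported), and in this assay compound 3 gives "not determined" (no result reported). Going by the values given here, no step between measured compounds can therefore be drawn, and compound 1 stands alone as the reference point. Compound 4 `COc1ccc(-c2cc(/C=C/C(=O)c3ccc(N)cc3)[nH]n2)cc1OC` is the next entry to be run in this assay. It differs from compound 1 in one place: methoxy in place of hydrogen on an aromatic carbon. Among the compounds with values here, no comparable step exists among the measured compounds, so the size of this step cannot be read from data. The expected step in this assay is a 1.2-fold lower number from compound 1 to compound 4 (0.09 log units; within the scatter), within the usual scatter or at most a modest gain. Compound 4 is accordingly expected to give about 2500 nM in this assay, with an estimated range from 800 nM to 8000 nM.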

Compound 4, concentration for 50% growth inhibition: 3580 nM
Compound 4: the middle estimate sits 1.4-fold (0.16 log units) below what was measured; low and high end bracket the measured number.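

In this assay, for the compounds shown here, methoxy in place of hydrogen on an aromatic carbon, ortho to a methoxy group and meta to a large group, gives a 1.2-fold higher number from compound 1 to compound 4 (0.06 log units; within the scatter) and is the first step with a number at both ends. At this position, then, the added methoxy produces no change that can be told apart from the scatter of the read-out. No measurement at hand bears on why the number holds here.

On these data alone, whether a hydroxy group, a fluorine atom or a longer chain such as ethoxy at this position would shift the number in this assay remains open. Steps to compound 2 and compound 3 cannot be read, so the effect of further methoxy groups on the shared core also remains open.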